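The compounds below may be only part of what the source reports. "The series", "measured", "known", "first", "only" and "open" are said of these compounds alone.

Measured compounds:
- compound 1 `Cc1c(C(=O)Nc2ccc(Oc3ccnc4[nH]ccc34)c(F)c2)nnn1-c1ccccc1` gives 350 nM in a functional assay on MCF7 cells (Homo sapiens) for cytotoxicity, read by MTT assay, with a stated time of 72 h; a higher number here means a weaker inhibitor, a lower number a stronger inhibitor
- compound 2 `Cc1c(C(=O)Nc2ccc(Oc3ccnc4[nH]ccc34)c(F)c2)nnn1-c1ccc(F)c(F)c1` gives 820 nM in this assay
- compound 3 `Cc1c(C(=O)Nc2ccc(Oc3ccnc4[nH]ccc34)cc2)nnn1-c1ccccc1` gives 320 nM in this assay

Compound 3 has the lowest number of the three, though compound 1 sits within the scatter of it, and only compound 2 lies clearly beyond it. Compound 4 `Cc1c(C(=O)Nc2ccc(Oc3ccnc4[nH]ccc34)cc2)nnn1-c1ccc(F)cc1` differs from compound 3 by fluoro in place of hydrogen on an aromatic carbon, the same difference, cut one bond further out, reading phenyl to 4-fluorophenyl on an aromatic nitrogen. Going by the values given here, one measured step bears on this: a 2.3-fold higher number from compound 1 to compound 2 (0.37 log units; beyond the scatter), where two fluorines entered the same ring. Compound 4 carries a single fluoro on that ring, so a smaller step is expected, probably a modestly higher number or none beyond the scatter. For compound 4 the estimate in this assay is 450 nM, between 220 nM and 950 nM, a step of a 1.4-fold higher number from compound 3 to compound 4 (0.15 log units; within the scatter) that is expected to stay close to the scatter.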

Compound 4, half-maximal inhibitory concentration: 390 nM
For compound 4 the middle estimate is 1.2-fold (0.06 log units) above the measured one; the range from low to high includes it.
By their numbers in this assay, from the lowest: compounds 3, 1 and 4 (each within the scatter of the next); then compound 2.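

In this assay, fluoro on the phenyl ring on the aromatic nitrogen, para to a large group, gives a 1.2-fold higher number from compound 3 to compound 4 (0.09 log units; within the scatter), so a single fluoro at this place leaves the number within the scatter. The earlier step, a 2.3-fold higher number from compound 1 to compound 2 (0.37 log units; beyond the scatter), involved 3,4-difluorophenyl and a core that also carries a fluoro on its other ring, so the two steps differ in more than the fluorine count on this ring. No measurement is available here to explain either step.

The compounds shown leave open whether the step to 3,4-difluorophenyl depends on the second fluoro on that ring or on the fluoro elsewhere in the core. They also leave open how chloro, methoxy, an amine or a carboxylic acid would fare at this place.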